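Cytotoxicity notes: acetyl for phenylsulfonyl on the shared core

The compounds below may be only part of what the source reports. "The series", "measured", "known", "first", "only" and "open" are said of these compounds alone.

Compound 2 `O=c1cc(N2CCN(CC3CCC(NS(=O)(=O)c4ccccc4)CC3)CC2)sc2c([N+](=O)[O-])cc(C(F)(F)F)cc12` has been read in an ADME assay on Vero cells (Chlorocebus sabaeus) for cytotoxicity, read by MTT assay, with a stated time of 48 h; a lower number here means a stronger inhibitor, a higher number a weaker inhibitor. In this assay compound 2 gives > 64 ug/mL, which is a limit of the assay and not a number. Compound 1 `O=C(OC1CCC(CN2CCN(c3cc(=O)c4cc(C(F)(F)F)cc([N+](=O)[O-])c4s3)CC2)CC1)c1cccc(C(F)(F)F)c1` gives > 64 ug/mL in this assay, also a limit. Compound 3 `O=C(OC1CCC(CN2CCN(c3cc(=O)c4cc(C(F)(F)F)cc([N+](=O)[O-])c4s3)CC2)CC1)c1ccc(C(F)(F)F)cc1` gives > 64 ug/mL in this assay, again a limit. Going by the values given here, the one measured step, a step that the two limits leave unreadable from compound 1 to compound 3, is therefore unreadable because the limit of > 64 ug/mL in this assay, at which 3 of the 3 values shown sit, holds every value in the set. Compound 4 `CC(=O)NC1CCC(CN2CCN(c3cc(=O)c4cc(C(F)(F)F)cc([N+](=O)[O-])c4s3)CC2)CC1` is not yet measured. It differs from compound 2 by acetyl in place of phenylsulfonyl on an amine nitrogen. Among the compounds with values here, no measured step covers acetyl in place of phenylsulfonyl on an amine nitrogen, and the values shown give no readable step of any kind, so the only footing is that all three compounds sit at the limit. The step that the limit leaves unreadable from compound 2 to compound 4 is expected to be none beyond the scatter, with compound 4 most likely reported as a limit as well. Compound 4 is expected to give about 100 ug/mL in this assay, within 50 ug/mL to 250 ug/mL.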

Compound 4, half-maximal inhibitory concentration: > 64 ug/mL
Compound 4: only a limit was reported; the forecaster's own chance of this, stated with the estimate: 85%; the middle value lies beyond the limit too.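

No step can be read between compound 2 and compound 4 in this assay, because both results are limits and not numbers: the limit of > 64 ug/mL in this assay, at which 4 of the 4 values shown sit.

The compounds shown leave open where any of them reaches half-maximal inhibition in this assay, and whether acetyl and phenylsulfonyl on the amine nitrogen differ there at all.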